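Dihydroxyphenyl variant of a series sitting at the limit

The source may hold more compounds than are shown below. What is called first, only, known or untested is meant among the compounds shown, and "the series" means these compounds.

Compound 3, `COc1cc(/C=N/NC(=O)Nc2ccc(Oc3ccnc(-c4nncn4CCN(C)C)c3)c(F)c2)ccc1O`, is one of three analogues that share a core and differ only in the aryl group on a carbon with a double bond to nitrogen. In a functional assay on U-87MG ATCC cells (Homo sapiens) for cytotoxicity, read by MTT assay, with a stated time of 72 h (on this read-out higher numbers stand for weaker inhibition and lower numbers for stronger inhibition), compound 3 returns > 100000 nM, which is a limit of the assay rather than a number. Compound 1, `CN(C)CCn1cnnc1-c1cc(Oc2ccc(NC(=O)N/N=C/c3cccc(O)c3)cc2F)ccn1`, likewise gives only the limit > 100000 nM in this assay. For the measured compounds named here, compound 2, `CN(C)CCn1cnnc1-c1cc(Oc2ccc(NC(=O)N/N=C/c3cccc(Cl)c3Cl)cc2F)ccn1`, is the sole analogue with a measured figure, 13200 nM in this assay. The steps read as an at least 7.5-fold lower number from compound 1 to compound 2 (0.87 log units; beyond the scatter), an at least 7.5-fold higher number from compound 2 to compound 3 (0.87 log units; beyond the scatter) and a step that the two limits leave unreadable from compound 1 to compound 3; two of the three values sit where (the limit of > 100000 nM in this assay, at which 2 of the 3 values shown sit). Compound 4, `CN(C)CCn1cnnc1-c1cc(Oc2ccc(NC(=O)N/N=C/c3ccc(O)cc3O)cc2F)ccn1`, is not yet measured. It differs from compound 3 by 2,4-dihydroxyphenyl in place of 4-hydroxy-3-methoxyphenyl on a carbon with a double bond to nitrogen. Both hydroxy-bearing analogues, compound 1 and compound 3, sit at the limit, and the two readable steps only single out compound 2; so compound 4 is expected to stay at or near the limit rather than move beyond the scatter. Compound 4 is therefore estimated at 150000 nM, with a range from 40000 nM to 600000 nM. This estimate means an expected step that the limit leaves unreadable from compound 3 to compound 4.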

Compound 4, half-maximal inhibitory concentration: 15400 nM
Estimate against measurement, compound 4: 9.7-fold (0.99 log units) above; measured number below the stated range.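

In this assay, a hydroxy-bearing aryl group does not by itself keep a compound at the limit: 2,4-dihydroxyphenyl on a carbon with a double bond to nitrogen gives an at least 6.4-fold lower number from compound 3 to compound 4 (0.81 log units; beyond the scatter) and an at least 6.4-fold lower number from compound 1 to compound 4 (0.81 log units; beyond the scatter). The dichlorinated aryl group also loses its standing as the only one with a measured figure, since the change gives a 1.2-fold higher number from compound 2 to compound 4 (0.07 log units; within the scatter), so these two aryl groups cannot be told apart in this assay. The true size of the two steps beyond the scatter stays unknown, as they start from limits and give only a minimum: the limit of > 100000 nM in this assay, at which 2 of the 4 values shown sit.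

The compounds shown do not settle whether the gain depends on having two hydroxy groups or on where they stand on the ring. A 2-hydroxyphenyl or a 2,4-dimethoxyphenyl group at this place would separate these readings.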